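Thiophene acid head-group swap on the biaryl ether series

A few compounds are considered here, and "the series" means these few. Any claim that something is new, unique, unknown or untested is made for them only; others in the source may bear on it.

Among the measured compounds shown here, three measured compounds so far. Compound 1 `Cc1cccc(C)c1-c1cccc(OCn2cc(CCC(=O)O)nn2)c1` in a functional assay on cells for agonist activity at Free fatty acid receptor 1 (Homo sapiens), read by calcium flux (a lower number here means that less compound is needed, a higher number that more compound is needed for the effect), gives 32200 nM. Compound 3 `COc1ccc(F)c(-c2cccc(COc3ccc(CCC(=O)O)s3)c2)c1` in this assay gives 580 nM. Compound 2 `Cc1cccc(C)c1-c1cccc(COc2ccc(CC3SC(=O)NC3=O)s2)c1` in this assay gives 82 nM, the lowest of the three numbers; compound 3 sits at the nearer distance and compound 1 at the far one, both beyond the scatter.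

Compound 4 `CCOC(CC(=O)O)c1ccc(OCc2cccc(-c3c(C)cccc3C)c2)s1` keeps the core of compound 2 and differs only in the head group: 2-carboxy-1-ethoxyethyl in place of (2,4-dioxo-1,3-thiazolidin-5-yl)methyl on an aromatic carbon. For the measured compounds named here, no single-point step between measured compounds covers this exchange. A modest rise in this assay is expected for compound 4, of about a 2.2-fold higher number from compound 2 to compound 4 (0.34 log units; beyond the scatter), given that compound 3 with a plain propanoic acid gives 580 nM. Compound 4 is therefore estimated at 180 nM, within 45 nM to 700 nM.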

Compound 4, half-maximal effective concentration: 57 nM
Estimate against measurement, compound 4: 3.2-fold (0.50 log units) above, within the range that was stated.
By their numbers in this assay, from the lowest: compounds 4 and 2 (each within the scatter of the next); then compound 3; then compound 1.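

In this assay, 2-carboxy-1-ethoxyethyl in place of (2,4-dioxo-1,3-thiazolidin-5-yl)methyl gives a 1.4-fold lower number from compound 2 to compound 4 (0.16 log units; within the scatter). On this aromatic carbon next to the ring sulfur, the shared core therefore carries a chain with no ring and a carboxylic acid as well as it carries the five-membered non-aromatic ring. No measured property bears on this result. The compounds shown leave open what the ethoxy part of the chain contributes, as no pair separates it from the acid. A hydroxyl or a methyl in its place on the chain would address this.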